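The source may hold more compounds than are shown below. What is called first, only, known or untested is meant among the compounds shown, and "the series" means these compounds.

Within the data shown here, compound 3 `Cc1cc(NCc2cccs2)n2nc(C)c(-c3ccccc3)c2n1` is the least soluble of the three compounds measured so far. In a physicochemical assay for solubility, read by HPLC, using the shake flask method, measured as kinetic solubility, with a stated time of 2 h, at pH 7.4 (on this read-out lower numbers stand for lower solubility and higher numbers for higher solubility), compound 3 gives only a limit, < 5000 nM, not a number. Compound 1 `Cc1cc(NCc2ccncc2)n2nc(C)c(-c3ccccc3)c2n1` gives 134000 nM and compound 2 `Cc1cc(NCc2ncccn2)n2nc(C)c(-c3ccccc3)c2n1` gives 37900 nM, with a 3.5-fold lower number from compound 1 to compound 2 (0.55 log units; beyond the scatter). Compound 4 `Cc1cc(NCc2ccc(F)cn2)n2nc(C)c(-c3ccccc3)c2n1` has not yet been measured in this assay; the change it makes is 5-fluoropyridin-2-yl in place of thiophen-2-yl on a saturated chain carbon bound to a nitrogen on an aromatic ring. Two measured steps ran the other way, from a six-membered ring to the thiophene: an at least 26-fold lower number from compound 1 to compound 3 (1.42 log units; beyond the scatter) and an at least 7.5-fold lower number from compound 2 to compound 3 (0.87 log units; beyond the scatter). Both end at the limit of < 5000 nM in this assay, at which 1 of the 3 values shown sits, so their true sizes may be larger. Reversing that direction, an upward step is therefore expected, an at least 8.0-fold higher number from compound 3 to compound 4 (0.90 log units; beyond the scatter). Compound 4 is estimated at 40000 nM, with a range from 8000 nM to 150000 nM.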

Compound 4, solubility: < 5000 nM
Compound 4: no number, only a limit (the forecaster's own chance of this, stated with the estimate: 15%); middle value at least 8.0-fold (0.90 log units) away from the limit.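

In this assay compound 4 gives only a limit, not a number, so a ring nitrogen at this position does not by itself secure a high number. The change to 5-fluoropyridin-2-yl gives an at least 7.5-fold lower number from compound 2 to compound 4 (0.87 log units; beyond the scatter) and an at least 26-fold lower number from compound 1 to compound 4 (1.42 log units; beyond the scatter). The step between compound 3 and compound 4 cannot be read, and the other two steps may be larger than printed because they end at a limit: the limit of < 5000 nM in this assay, at which 2 of the 4 values shown sit.

On these data alone, whether the fluorine or the way the ring is attached matters more remains open. Plain pyridin-2-yl, without the fluorine, would separate the two.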